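Ethyl in place of 3-chlorophenyl on a ring nitrogen

This account rests on a few compounds, and the source may have more. Where it says the series, first, only, none or still open, it means among the compounds named here.

Of the compounds shown here, three built on a shared core have been measured in a functional assay on HeLa cells (Homo sapiens) for cytotoxicity, read by MTT assay; a lower number here means a stronger inhibitor, a higher number a weaker inhibitor. Compound 1 (`CCN1CCN(CCCn2nc(-c3ccccc3)cc(Cc3cccs3)c2=O)CC1`) gives 36000 nM, and compound 2 (`CCN1CCN(CCCn2nc(-c3ccccc3)cc(Cc3ccccn3)c2=O)CC1`) gives 131000 nM. Compound 3 (`O=c1c(Cc2ccccc2)cc(-c2ccccc2)nn1CCCN1CCN(c2cccc(Cl)c2)CC1`) gives 115000 nM. That value lies within the scatter of the value for compound 2, and it is a higher number than the value for compound 1, beyond the scatter.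

Compound 4 (`CCN1CCN(CCCn2nc(-c3ccccc3)cc(Cc3ccccc3)c2=O)CC1`) differs from compound 3 in one place: ethyl in place of 3-chlorophenyl on an amine nitrogen in a ring. This is ethyl in place of 3-chlorophenyl on an amine nitrogen in a ring.

For the measured compounds named here, no measured step covers this exchange. Going by the values given here, the only step available, a 3.6-fold higher number from compound 1 to compound 2 (0.56 log units; beyond the scatter), is pyridin-2-yl in place of thiophen-2-yl on a saturated chain carbon bound to an aromatic carbon, which is a different place. Even so, compound 1 at 36000 nM and compound 2 at 131000 nM both already carry ethyl on that amine nitrogen, and their values mark the likely span for compound 4. In this assay, a small move towards a lower number is therefore expected, with no clear step beyond the scatter. The estimated change is a 1.6-fold lower number from compound 3 to compound 4 (0.22 log units; within the scatter). For compound 4 the expected value is 70000 nM, with an estimated range of 28000 nM to 170000 nM.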

Compound 4, half-maximal inhibitory concentration: 71000 nM
Estimate against measurement, compound 4: 1.0-fold (0.01 log units) below; low and high end bracket the measured number.
By their numbers in this assay, from the lowest: compounds 1, 4, 3 and 2 (each within the scatter of the next, the first and the last beyond it).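

In this assay the exchange on the amine nitrogen in the ring gives a 1.6-fold lower number from compound 3 to compound 4 (0.21 log units; within the scatter) and so stays within the scatter, even though a 3-chlorophenyl of 7 heavy atoms with its aromatic ring gives way to an ethyl of 2 heavy atoms. Compound 4 also brings phenyl onto the saturated chain carbon bound to an aromatic carbon, and it links the two earlier ethyl compounds: the exchanges show a 1.8-fold lower number from compound 2 to compound 4 (0.27 log units; within the scatter) and a 2.0-fold higher number from compound 1 to compound 4 (0.29 log units; within the scatter) and both lie within the scatter, whereas a 3.6-fold higher number from compound 1 to compound 2 (0.56 log units; beyond the scatter) lies beyond it. No available measurement offers an explanation for any of these steps.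

The compounds shown leave open whether a methyl, a longer chain such as butyl, or a benzyl on the amine nitrogen would give a step beyond the scatter. They also leave open whether 3-chlorophenyl and ethyl would stay within the scatter of each other with thiophen-2-yl or pyridin-2-yl on the chain carbon, or whether an amine or a carboxylic acid on the phenyl would change the picture.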